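Swapping the aryl group beside the carbonyl on a boron core

A few compounds are considered here, and "the series" means these few. Any claim that something is new, unique, unknown or untested is made for them only; others in the source may bear on it.

Three measured compounds share a common core and differ only in the aromatic group attached to a carbonyl carbon. Compound 1 `Cn1cccc1C(=O)/C=C/c1ccc2c(c1)B(O)OC2` carries a 1-methyl-1H-pyrrol-2-yl there. In a toxicity assay on WI-38 cells (Homo sapiens) for cytotoxicity, read by MTT assay, with a stated time of 48 h (a lower number here means a stronger inhibitor, a higher number a weaker inhibitor), compound 1 reaches only a limit, > 100000 nM, namely (the limit of > 100000 nM in this assay, at which 1 of the 3 values shown sits). Compound 2 `O=C(/C=C/c1ccc2c(c1)B(O)OC2)c1ccc(Cl)cc1` carries a 4-chlorophenyl, and in this assay compound 2 gives 24700 nM. Compound 3 `Nc1ccc(C(=O)/C=C/c2ccc3c(c2)B(O)OC3)cc1` carries a 4-aminophenyl, and in this assay compound 3 gives 25400 nM. Compound 3 thus stands alongside compound 2: the gap a 1.0-fold higher number from compound 2 to compound 3 (0.01 log units; within the scatter) is within the scatter, so neither can be called the weaker. Among the compounds with values here, the only steps beyond the scatter are those away from the pyrrole, an at least 4.0-fold lower number from compound 1 to compound 2 (0.60 log units; beyond the scatter) and an at least 3.9-fold lower number from compound 1 to compound 3 (0.59 log units; beyond the scatter).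

Compound 4 `O=C(/C=C/c1ccc2c(c1)B(O)OC2)c1cccc(O)c1` is reached by 3-hydroxyphenyl in place of 4-aminophenyl on a carbonyl carbon. Within the data shown here, the one measured exchange of a group on that phenyl ring, a 1.0-fold higher number from compound 2 to compound 3 (0.01 log units; within the scatter), left the number essentially unchanged, and that is the step that bears on this change. No step beyond the scatter is therefore expected in this assay; the expected step is a 1.0-fold lower number from compound 3 to compound 4 (0.01 log units; within the scatter). For compound 4 the estimated value in this assay is 25000 nM, with a range from 10000 nM to 65000 nM.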

Compound 4, half-maximal inhibitory concentration: 26400 nM
The estimate for compound 4 lay 1.1-fold (0.02 log units) below the measured number; measured number inside the range.
By their numbers in this assay, from the lowest: compounds 2, 3 and 4 (each within the scatter of the next). At a limit, above all of these: compound 1.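

The earlier phenyl groups, 4-chlorophenyl and 4-aminophenyl, both carry their group under the same number in the name, so 3-hydroxyphenyl changes both the group and its place on the ring. Even so, in this assay the result is a 1.0-fold higher number from compound 3 to compound 4 (0.02 log units; within the scatter) and a 1.1-fold higher number from compound 2 to compound 4 (0.03 log units; within the scatter), so these three phenyl groups cannot be told apart here, whichever of the two changes is considered. On these data alone, the step from the 1-methyl-1H-pyrrol-2-yl group remains the only kind beyond the scatter, an at least 3.7-fold lower number from compound 1 to compound 4 (0.57 log units; beyond the scatter), and its true size stays unknown because compound 1 stands at a limit rather than at a number: the limit of > 100000 nM in this assay, at which 1 of the 4 values shown sits.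

The compounds shown do not separate the effect of the group from that of its place, which would take a pair such as 3-aminophenyl and 4-hydroxyphenyl alongside the compounds here. They also leave open whether an unsubstituted phenyl, a phenyl bearing a carboxylic acid, or a pyrrole without its methyl group would give a number near these phenyl compounds or one nearer the limit.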